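Removing the carboxy group from compound 1

A few compounds are considered here, and "the series" means these few. Any claim that something is new, unique, unknown or untested is made for them only; others in the source may bear on it.

Compound 1 `Cc1ccc(-c2nc3ccccc3s2)cc1NC(=O)c1cc([N+](=O)[O-])c(N2CCC(C(=O)O)CC2)cc1Cl` gives > 25000 nM
Compound 2 `O=C(Nc1ccc(-c2ccccc2)cc1)c1cc([N+](=O)[O-])ccc1Cl` gives > 27000 nM

Both compounds were tested in an ADME assay on BJ cells (Homo sapiens) for cytotoxicity, with a stated time of 72 h (on this read-out higher numbers stand for an effect only at larger amounts of compound and lower numbers for an effect already at smaller amounts), and neither result gives a measured number. In this assay compound 1 gives > 25000 nM and this is a limit of the assay. Compound 2 gives > 27000 nM and this too is a limit. Within the data shown here, the two results therefore set no order between the compounds, and compound 1 has no measured neighbour to be placed against.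

The next compound to be tested is compound 3 `Cc1ccc(-c2nc3ccccc3s2)cc1NC(=O)c1cc([N+](=O)[O-])c(N2CCCCC2)cc1Cl`, which keeps the core of compound 1 and changes one group. The change hydrogen in place of carboxy on a saturated ring carbon puts hydrogen in place of carboxy on a saturated ring carbon, so that 4-carboxypiperidin-1-yl becomes piperidin-1-yl.

Among the measured compounds shown here, no measured pair shows what such a change does in this assay. The expectation therefore rests on compound 1 with its limit of > 25000 nM and allows only a modest shift toward lower numbers. The expected change is an at least 1.3-fold lower number from compound 1 to compound 3 (0.14 log units; that floor lies within the scatter) and it may stay hidden at the limit. For compound 3 the estimated value is 18000 nM within an expected range from 5000 nM to 30000 nM and the measurement is still to come.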

Compound 3, half-maximal effective concentration: > 25000 nM
Compound 3 ended at the assay's limit; the forecaster's own chance of this, stated with the estimate: 60%; at least 1.3-fold (0.14 log units) between middle value and limit.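

In this assay compound 3 gives > 25000 nM, which is a limit of the assay. Compound 1 gives > 25000 nM, also a limit, so no step can be read between compound 1 and compound 3. The compounds shown leave open at what concentration either would act on these cells, and whether replacing carboxy with hydrogen changes that concentration.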